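Three compounds and the step to a fluorinated benzyl

The source may hold more compounds than are shown below. What is called first, only, known or untested is meant among the compounds shown, and "the series" means these compounds.

Measured in a functional assay on PC-3 cells (Homo sapiens) for antiproliferative activity, read by MTT assay, with a stated time of 48 h (on this read-out lower numbers stand for stronger inhibition and higher numbers for weaker inhibition), are:
- compound 1 (`COc1ccc(CN(C(=O)CSc2nc3ccccc3s2)c2cc(OC)c(OC)c(OC)c2)cc1C`): 34300 nM
- compound 2 (`COc1cc(CN(C(=O)CSc2nc3ccccc3s2)c2cc(OC)c(OC)c(OC)c2)cc(OC)c1OC`): > 80000 nM as a limit of the assay
- compound 3 (`COc1cc(N(Cc2ccccc2)C(=O)CSc2nc3ccccc3s2)cc(OC)c1OC`): 54100 nM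

The gap to its nearest neighbour (a 1.6-fold higher number from compound 1 to compound 3 (0.20 log units; within the scatter)) lies within the scatter, which leaves compound 3 level with compound 1, and compound 2 gives only a limit. Compound 4 (`COc1ccc(CN(C(=O)CSc2nc3ccccc3s2)c2cc(OC)c(OC)c(OC)c2)cc1F`) carries 3-fluoro-4-methoxyphenyl in place of phenyl on a saturated chain carbon bound to an amide-type nitrogen. The closest measured change, phenyl in place of 4-methoxy-3-methylphenyl (a 1.6-fold higher number from compound 1 to compound 3 (0.20 log units; within the scatter)), stayed within the scatter, whereas 3,4,5-trimethoxyphenyl in place of 4-methoxy-3-methylphenyl (an at least 2.3-fold higher number from compound 1 to compound 2 (0.36 log units; beyond the scatter)) went beyond it. No step beyond the scatter is therefore expected in this assay and the estimated shift is small (a 1.4-fold lower number from compound 3 to compound 4 (0.15 log units; within the scatter)). Compound 4 is expected near 38000 nM with an estimated range from 17000 nM to 78000 nM in this assay.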

Compound 4, half-maximal inhibitory concentration: 20100 nM
The estimate for compound 4 lay 1.9-fold (0.28 log units) above the measured number, and the stated range covers the measured number.
By their numbers in this assay, from the lowest: compounds 4, 1 and 3 (each within the scatter of the next, the first and the last beyond it). At a limit, above all of these: compound 2.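

In this assay, among these compounds, 3-fluoro-4-methoxybenzyl is the first group at this place to stand beyond the scatter from plain benzyl (a 2.7-fold lower number from compound 3 to compound 4 (0.43 log units; beyond the scatter)), which the 4-methoxy-3-methylphenyl of compound 1 did not do. Yet fluoro in place of methyl on an aromatic carbon stays within the scatter (a 1.7-fold lower number from compound 1 to compound 4 (0.23 log units; within the scatter)), which leaves compound 1 and compound 4 level. Compound 2 gives only a limit, so its step (an at least 3.9-fold lower number from compound 2 to compound 4 (0.59 log units; beyond the scatter)) is a floor: the limit of > 80000 nM in this assay, at which 1 of the 4 values shown sits.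

The compounds shown leave open how chloro or nitrile in place of the fluoro would read. They also leave open whether 3-fluorobenzyl without the methoxy would keep this step.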